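The source may report more compounds than this note shows. Statements on the series, on what has been measured and on what is new or still open speak of the compounds shown alone.

Of the compounds shown here, three built on a shared core have been measured in a functional assay on MT2 cells (Homo sapiens) for cytotoxicity, read by MTT assay; a lower number here means that less compound is tolerated, a higher number that more compound is tolerated. Compound 1 `Clc1ccc(Nc2nccs2)cc1OCc1nccs1` gives 20000 nM in this assay. Compound 2 `N#Cc1ccc(Nc2nccs2)cc1OCc1nccs1` differs from compound 1 by cyano in place of chloro on an aromatic carbon, and in this assay compound 2 gives 20000 nM. The step of no change at the digits printed from compound 1 to compound 2 (within the scatter) lies within the scatter. Compound 3 `Clc1ccc(Nc2nccs2)cc1OCC1=CCCC1` carries a different core, which differs from the core of compound 1 by cyclopent-1-en-1-yl in place of 1,3-thiazol-2-yl on a saturated chain carbon bound to an oxygen on an aromatic ring. In this assay compound 3 gives 15000 nM. The step of a 1.3-fold lower number from compound 1 to compound 3 (0.12 log units; within the scatter) is also within the scatter, so the three measured numbers sit close together and none of the compounds can be set apart from the others.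

Compound 4 `N#Cc1ccc(Nc2nccs2)cc1OCC1=CCCC1` has not yet been measured in this assay. It stands to compound 3 as compound 2 stands to compound 1: the difference is cyano in place of chloro on an aromatic carbon, and the surroundings of the place are described in the same words for both pairs, so this is the same change made on the other core. Because the earlier instance no change at the digits printed from compound 1 to compound 2 (within the scatter) stayed within the scatter, the step is expected to be no change at the digits printed from compound 3 to compound 4 (within the scatter), with no real movement in either direction. Going by the values given here, compound 4 is accordingly estimated at 15000 nM in this assay, with a likely range from 8000 nM to 30000 nM, an expectation that rests only on the single measured instance of this change and on the flat result across the three measured compounds.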

Compound 4, half-maximal cytotoxic concentration: 1700 nM
Compound 4: middle estimate off by 8.8-fold (0.95 log units), on the high side, and the stated range ends above it.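

In this assay, cyano in place of chloro gives an 8.8-fold lower number from compound 3 to compound 4 (0.95 log units; beyond the scatter), so this change does not carry over at the same size from the core of compound 1 to the core of compound 3: the same change on two cores in this assay, no change at the digits printed (within the scatter) from compound 1 to compound 2 and an 8.8-fold lower number (0.95 log units; beyond the scatter) from compound 3 to compound 4, 8.8-fold (0.95 log units) apart, beyond the scatter of two such steps. Read along the other edge of the same four compounds, cyclopent-1-en-1-yl in place of 1,3-thiazol-2-yl gives a 12-fold lower number from compound 2 to compound 4 (1.07 log units; beyond the scatter), and this change too differs with what the aromatic carbon carries: the same change on two cores in this assay, a 1.3-fold lower number (0.12 log units; within the scatter) from compound 1 to compound 3 and a 12-fold lower number (1.07 log units; beyond the scatter) from compound 2 to compound 4, 8.8-fold (0.95 log units) apart, beyond the scatter of two such steps. The two changes therefore do not simply add up in this series, since only the pairing of cyano with cyclopent-1-en-1-yl in compound 4 stands apart, but this rests on a single set of four compounds and does not show why the pairing behaves this way or whether the same would hold on any other core.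

The compounds shown leave open whether a bromo or a methoxy group on that aromatic carbon would follow cyano or chloro when cyclopent-1-en-1-yl is present. They also leave open whether a saturated cyclopentyl or a phenyl ring on the chain would give the same lower number alongside cyano.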